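A few compounds are considered here, and "the series" means these few. Any claim that something is new, unique, unknown or untested is made for them only; others in the source may bear on it.

Working notes on the series. Compound 1 `C=CCn1c(SCC(=O)Nc2ccc(C(C)=O)cc2)nnc1-c1ccccc1` carries an allyl group on the aromatic nitrogen and no methoxy group; in a functional assay on the whole organism (strain albino) for inhibition, with Rattus norvegicus as the target, read by paw edema, with stated times of 30 min and 1 h, at a dose of 0.28 mmol/kg by the oral route (on this read-out higher numbers stand for more inhibition at the one dose given (going by the name of the read-out) and lower numbers for less inhibition), compound 1 gives 48%. Compound 2 `CCn1c(SCC(=O)Nc2ccc(C(C)=O)cc2)nnc1-c1ccc(OC)c(OC)c1` has an ethyl group there and two methoxy groups; compound 2 gives 56%. Compound 3 `CCn1c(SCC(=O)Nc2ccc(C(C)=O)cc2)nnc1-c1ccc(OC)cc1` keeps the ethyl group and one methoxy group; compound 3 gives 51%. Compound 3 thus stands second highest of the three numbers, nearest to compound 1 and furthest from compound 2, though both gaps lie within the scatter. Among the compounds with values here, the only one-place step among the measured compounds, a number 5 percentage points lower from compound 2 to compound 3 (within the scatter), is likewise within the scatter.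

Compound 4 `C=CCn1c(SCC(=O)Nc2ccc(C(C)=O)cc2)nnc1-c1ccc(OC)cc1` is the next member. Relative to compound 3 the change is vinyl in place of methyl on a saturated chain carbon bound to an aromatic nitrogen. Within the data shown here, no measured one-place step bears directly on this change. Compounds 1 and 3 differ at this place and at the methoxy group together; compound 1 gives 48% and compound 3 gives 51%, two values within the scatter of each other, so nothing beyond the scatter is indicated for the ethyl-to-allyl change. The step of a number 1 percentage points lower from compound 3 to compound 4 (within the scatter) is therefore expected to stay within the scatter. Compound 4 is estimated to give 50%, with a range from 40% to 60%.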

Compound 4, a percentage reported as inhibition, in the whole organism at one dose (the size of the read-out at that dose, not a potency): 50%
For compound 4 middle estimate and measured number coincide at the digits printed; measured number inside the range.
By their numbers in this assay, from the lowest: compounds 1, 4, 3 and 2 (each within the scatter of the next).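

In this assay, the exchange at the saturated chain carbon bound to an aromatic nitrogen can now be read on its own, where compounds 1 and 3 differed in two places at once: vinyl in place of methyl, or ethyl to allyl when cut one bond further out, gives a number 1 percentage points lower from compound 3 to compound 4 (within the scatter). Within the data shown here, on the allyl side, the methoxy group can also be read alone for the first time, with methoxy in place of hydrogen on an aromatic carbon giving a number 2 percentage points higher from compound 1 to compound 4 (within the scatter). The methoxy change has therefore been seen with both ethyl and allyl in place, and the two readings agree: the same change on two cores in this assay, a number 5 percentage points lower (within the scatter) from compound 2 to compound 3 and a number 2 percentage points lower (within the scatter) from compound 4 to compound 1, 3 percentage points apart, within the scatter of two such steps.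

The compounds shown hold only ethyl and allyl at this place, both within the scatter of each other on the one-methoxy core, so whether a longer chain such as butyl, or a chain ending in an amine or a carboxylic acid, would give a step beyond the scatter stays open. Likewise open, on these data alone, is whether a group other than methoxy on the aromatic carbon, such as chlorine or hydroxyl, would move the number further than the steps seen so far.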